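One Ring Swap from Compound 2 to Compound 3

This account rests on a few compounds, and the source may have more. Where it says the series, first, only, none or still open, it means among the compounds named here.

Measured so far in an ADME assay on the whole organism (Rattus norvegicus) for pharmacokinetics, at a dose of 3 mg/kg by the oral route; on this read-out lower numbers stand for lower exposure and higher numbers for higher exposure at the dose given:
- Compound 1 `Cc1ccc(Cn2c(Nc3ccc(OC(C)C)c(Cl)c3)nc(=O)n(CCC(=O)O)c2=O)cc1`: 14300 ng.h/mL
- Compound 2 `C[C@@H](Cn1c(=O)[nH]/c(=N\c2ccc(Oc3ccccn3)cc2)n(Cc2ccc(Cl)cc2)c1=O)C(=O)O`: 14000 ng.h/mL

These two numbers lie within the usual scatter of repeated measurements, so compound 2 cannot be told apart from compound 1 on this read-out. Among the measured compounds shown here, two values also give only a thin basis for prediction, and no two measured compounds differ in a single place.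

Compound 3 `C[C@@H](Cn1c(=O)[nH]/c(=N\c2ccc(Oc3ccnc(F)c3)cc2)n(Cc2ccc(Cl)cc2)c1=O)C(=O)O` is compound 2 with one group exchanged: 2-fluoropyridin-4-yl in place of pyridin-2-yl on an oxygen on an aromatic ring. Put simply, 2-fluoropyridin-4-yl stands in place of pyridin-2-yl on an oxygen on an aromatic ring. For the measured compounds named here, no measured pair shows what this exchange does to exposure, so the starting point is compound 2 at 14000 ng.h/mL. The expected change is small and downward, and it is not expected to go beyond the scatter: the estimated move is a 1.3-fold lower number from compound 2 to compound 3 (0.10 log units; within the scatter). With so little to go on, the expected range stays wide. For compound 3 the estimated value is 11000 ng.h/mL, with an expected range of 4000 ng.h/mL to 28000 ng.h/mL.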

Compound 3, area under the concentration-time curve: 4020 ng.h/mL
For compound 3 the middle estimate is 2.7-fold (0.44 log units) above the measured one; the range from low to high includes it.
By their numbers in this assay, from the lowest: compound 3; then compounds 2 and 1 (each within the scatter of the next).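

Among the compounds shown here, exchanging pyridin-2-yl for 2-fluoropyridin-4-yl on an oxygen on an aromatic ring is the first change in this set that can be read in a single place, and in this assay it gives a 3.5-fold lower number from compound 2 to compound 3 (0.54 log units; beyond the scatter). This shows that exposure after an oral dose is sensitive to what sits at this position, even though both groups are six-membered aromatic rings with 1 hetero atom, the same counts of hydrogen-bond donors and acceptors, and no net charge. No measurement here bears on why the number falls.

This single step combines two differences, the added fluorine and the move from a pyridin-2-yl to a pyridin-4-yl ring, and the compounds shown cannot separate their contributions. A plain pyridin-4-yl group on the same oxygen would help to separate them, while a 2-chloropyridin-4-yl or a phenyl group would show whether the lower number is particular to this fluorinated ring.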